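A Fluoro for Methoxy Swap on the Aniline Ring

A few compounds are considered here, and "the series" means these few. Any claim that something is new, unique, unknown or untested is made for them only; others in the source may bear on it.

Among the measured compounds shown here, compound 3 `COc1ccc(OC)c(Nc2cc(NC(=O)Nc3c(Cl)cccc3Cl)ncn2)c1` stands highest of the three numbers measured so far in a functional assay on NCI-H1581 cells (Homo sapiens) for inhibition, read by MTT assay, with a stated time of 48 h, tested at 10 uM; on this read-out higher numbers stand for more inhibition at the one concentration tested (going by the name of the read-out) and lower numbers for less inhibition: compound 3 gives 93.1%. The nearest figure belongs to compound 2 `CCc1ccc(Nc2cc(NC(=O)Nc3c(Cl)cccc3Cl)ncn2)cc1`, which in this assay gives 38.1%, a number lower by a margin beyond the usual scatter. Furthest away is compound 1 `COc1cc(NC(=O)Nc2cc(Nc3cc(Br)ccc3OC)ncn2)cc(OC)c1`, which in this assay gives 23.1%, again beyond the scatter. For the measured compounds named here, no two of these three compounds differ in only one place, so no measured single-point step is available.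

Compound 4 `COc1ccc(F)cc1Nc1cc(NC(=O)Nc2c(Cl)cccc2Cl)ncn1` has not yet been measured. It differs from compound 3 in a single place: fluoro in place of methoxy on an aromatic carbon. The change sits on an aromatic carbon of a six-membered aromatic ring of carbon only, meta to a large group and para to a methoxy group.

Compound 2 and compound 1, which both carry different groups on that ring, fall far below compound 3, which suggests that what stands on this ring matters, although no single-point comparison fixes the size of any one change. The account therefore expects a downward step beyond the scatter, with the estimated step from compound 3 to compound 4 being a number 33.1 percentage points lower from compound 3 to compound 4 (beyond the scatter). Compound 4 is expected to give about 60%, within a range from 30% to 88%.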

Compound 4, a percentage reported as inhibition, at one concentration (the size of the read-out at that concentration, not a potency): 73.1%
Compound 4: the middle estimate sits 13.1 percentage points below what was measured; low and high end bracket the measured number.
By their numbers in this assay, from the lowest: compound 1; then compound 2; then compound 4; then compound 3.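

Fluoro in place of methoxy on this aromatic carbon, para to a methoxy group, gives the first single-place reading at this position: in this assay the result is a number 20 percentage points lower from compound 3 to compound 4 (beyond the scatter). The methoxy at this carbon therefore contributes to the high number of compound 3, yet it is not essential for substantial inhibition, since the fluoro analogue remains well above compound 2. The second comparison, 5-fluoro-2-methoxyphenyl in place of 4-ethylphenyl on a nitrogen on an aromatic ring, gives a number 35 percentage points higher from compound 2 to compound 4 (beyond the scatter), showing that the identity of the whole aryl group on that nitrogen also has a clear effect on the read-out.

The compounds shown leave open whether a chloro, a hydroxyl, an amine or a longer ether such as ethoxy at this carbon would stay closer to compound 3 or fall further, and a reading at one concentration gives no potency for any of them. Nothing available here accounts for the loss on going from methoxy to fluoro, so its origin remains unexplained.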